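Halogen swap carried onto the fluorinated core

The source may hold more compounds than are shown below. What is called first, only, known or untested is meant among the compounds shown, and "the series" means these compounds.

Compound 1 `Cn1ccc2c(Oc3ccc(NC(=O)c4cc5cccnc5n(-c5ccc(Cl)cc5)c4=O)cc3)ncnc21` in a functional assay on A549 cells (Homo sapiens) for cytotoxicity, read by MTT assay, with a stated time of 72 h (on this read-out higher numbers stand for weaker inhibition and lower numbers for stronger inhibition), gives 75500 nM. Compound 2 `Cn1ccc2c(Oc3ccc(NC(=O)c4cc5cccnc5n(-c5ccc(Br)cc5)c4=O)cc3)ncnc21` differs from it by bromo in place of chloro on an aromatic carbon and gives 52200 nM; the step is a 1.4-fold lower number from compound 1 to compound 2 (0.16 log units; within the scatter). Compound 3 `Cn1ccc2c(Oc3ccc(NC(=O)c4cc5cccnc5n(-c5ccc(Cl)cc5)c4=O)cc3F)ncnc21` differs from compound 1 by fluoro in place of hydrogen on an aromatic carbon, the step being a 1.4-fold lower number from compound 1 to compound 3 (0.13 log units; within the scatter). In this assay compound 3 gives 55500 nM. Compound 4 `Cn1ccc2c(Oc3ccc(NC(=O)c4cc5cccnc5n(-c5ccc(Br)cc5)c4=O)cc3F)ncnc21` is not yet measured. It differs from compound 3 by bromo in place of chloro on an aromatic carbon, the same change as that between compound 1 and compound 2, here made on the core of compound 3 rather than the core of compound 1. A step of similar size is expected, so compound 4 is estimated to move by a 1.4-fold lower number from compound 3 to compound 4 (0.14 log units; within the scatter). That rests on compound 3 at 55500 nM and on the earlier step of a 1.4-fold lower number from compound 1 to compound 2 (0.16 log units; within the scatter), which stayed within the scatter. In this assay compound 4 is expected near 40000 nM, between 20000 nM and 80000 nM.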

Compound 4, half-maximal inhibitory concentration: 42200 nM
For compound 4 the middle estimate is 1.1-fold (0.02 log units) below the measured one, within the range that was stated.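

In this assay bromo in place of chloro gives a 1.3-fold lower number from compound 3 to compound 4 (0.12 log units; within the scatter) on the fluorinated core, and this step agrees with the one on the core of compound 1: the same change on two cores in this assay, a 1.4-fold lower number (0.16 log units; within the scatter) from compound 1 to compound 2 and a 1.3-fold lower number (0.12 log units; within the scatter) from compound 3 to compound 4, 1.1-fold (0.04 log units) apart, within the scatter of two such steps.
Fluoro in place of hydrogen on the bromo compounds gives a 1.2-fold lower number from compound 2 to compound 4 (0.09 log units; within the scatter) and likewise agrees with its earlier step: the same change on two cores in this assay, a 1.4-fold lower number (0.13 log units; within the scatter) from compound 1 to compound 3 and a 1.2-fold lower number (0.09 log units; within the scatter) from compound 2 to compound 4, 1.1-fold (0.04 log units) apart, within the scatter of two such steps.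
Going by these compounds alone, all of these steps lie within the scatter, so the agreement shows only that neither change moves the number detectably on either core, not that a real effect of either change carries from one core to the other.

Still open, going by these compounds, is whether a group other than a halogen, such as an amine or a carboxylic acid in place of the chloro or bromo, would give a step beyond the scatter.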